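This account rests on a few compounds, and the source may have more. Where it says the series, first, only, none or still open, it means among the compounds named here.

Going by the values given here, compound 1 `Cc1ccc(-c2nc3ccccc3[nH]2)cc1NC(=S)NC(=O)c1ccc2c(c1)OCCO2` is measured in a functional assay on HUVEC cells (Homo sapiens) for cytotoxicity, read by WST assay, with a stated time of 48 h (on this read-out higher numbers stand for weaker inhibition and lower numbers for stronger inhibition), where compound 1 gives 240 nM, the only plain number among the three entries of this series. Compound 2 `Cc1ccc(-c2nc3ccccc3[nH]2)cc1NC(=S)NC(=O)c1ccccc1` reaches only a limit of the assay, > 10000 nM, in this assay. Compound 3 `CCOc1ccc(C(=O)NC(=S)Nc2cc(-c3nc4ccccc4[nH]3)ccc2C)cc1OCC` has no result in this assay, recorded as "not determined" (no result reported). Among the compounds with values here, the single measured step, an at least 41-fold higher number from compound 1 to compound 2 (1.61 log units; beyond the scatter), arises from phenyl in place of 2,3-dihydro-1,4-benzodioxin-6-yl on a carbonyl carbon, and its size rests on (the limit of > 10000 nM in this assay, at which 1 of the 3 values shown sits).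

Compound 4 `O=C(NC(=S)Nc1cccc(-c2nc3ccccc3[nH]2)c1)c1ccc2c(c1)OCCO2` differs from compound 1 at a different position: hydrogen in place of methyl on an aromatic carbon. The methyl sits on an aromatic carbon of a six-membered aromatic ring of carbon only, far from the carbonyl carbon changed between compound 1 and compound 2, so that step gives no direct guide to the present change. With nothing measured at this position, a small step is expected, most likely within the scatter or slightly toward a higher number. The estimate for compound 4 in this assay is 400 nM, with a range from 150 nM to 1500 nM, which would mean an expected step of a 1.7-fold higher number from compound 1 to compound 4 (0.22 log units; within the scatter).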

Compound 4, half-maximal inhibitory concentration: 50 nM
The estimate for compound 4 lay 8.0-fold (0.90 log units) above the measured number; the whole stated range lies above it.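

Until now this position had carried only methyl, so the series could not show whether that group was needed; in this assay, hydrogen in its place gives a 4.8-fold lower number from compound 1 to compound 4 (0.68 log units; beyond the scatter). The methyl is therefore not required for the inhibition seen with compound 1, and this position, ortho to a large group and para to a 1H-benzimidazol-2-yl group, responds to a change of a single carbon. No measurement among those shown bears on why this step occurs.

As far as these compounds go, whether fluorine, a methoxy group or a hydroxyl group at this position would match hydrogen remains open. Also open, from the compounds shown here alone, is whether the same change would matter with phenyl on the carbonyl carbon, as in compound 2, whose > 10000 nM is a limit of the assay.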